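A few compounds are considered here, and "the series" means these few. Any claim that something is new, unique, unknown or untested is made for them only; others in the source may bear on it.

Three members of this series have been run in a functional assay on HCT-116 cells (Homo sapiens) for antiproliferative activity, read by MTT assay, with a stated time of 48 h; on this read-out higher numbers stand for weaker inhibition and lower numbers for stronger inhibition. Compound 1 `CS(=O)(=O)c1ccc(Nc2ncc(F)c(Nc3nc4ccccc4s3)n2)cc1` gives 3270 nM and compound 2 `COc1ccc2nc(Nc3nc(Nc4ccc(S(C)(=O)=O)cc4)ncc3F)sc2c1` gives 2630 nM in this assay; the two differ by hydrogen in place of methoxy on an aromatic carbon, and the step of a 1.2-fold higher number from compound 2 to compound 1 (0.09 log units; within the scatter). Compound 3 `COc1ccc2nc(Nc3ccnc(Nc4ccc(S(N)(=O)=O)cc4)n3)sc2c1` gives 1480 nM in this assay, a number whose distance from compound 2 lies within the scatter and whose distance from compound 1 lies just beyond it. The difference between the core of compound 3 and the core of compound 2 is not broken down here.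

Compound 4 `NS(=O)(=O)c1ccc(Nc2nccc(Nc3nc4ccccc4s3)n2)cc1` has not yet been measured. Within the data shown here, it differs from compound 3 by hydrogen in place of methoxy on an aromatic carbon, the same change at the same place as the one separating compound 2 from compound 1. Because the earlier instance gave a 1.2-fold higher number from compound 2 to compound 1 (0.09 log units; within the scatter), the expected step is a 1.2-fold higher number from compound 3 to compound 4 (0.09 log units; within the scatter), a change of similar small size in this assay. Compound 4 is therefore estimated at 1800 nM in this assay, with an expected range from 900 nM to 3600 nM.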

Compound 4, half-maximal inhibitory concentration: 5170 nM
The estimate for compound 4 lay 2.9-fold (0.46 log units) below the measured number; measured number above the stated range.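

In this assay, hydrogen in place of methoxy gives a 3.5-fold higher number from compound 3 to compound 4 (0.54 log units; beyond the scatter), and the size of this step on one core does not predict its size on the other: the same change on two cores in this assay, a 1.2-fold higher number (0.09 log units; within the scatter) from compound 2 to compound 1 and a 3.5-fold higher number (0.54 log units; beyond the scatter) from compound 3 to compound 4, 2.8-fold (0.45 log units) apart, beyond the scatter of two such steps

The step on the core of compound 3 lies beyond the scatter and the earlier one does not, so these two pairs do not establish a shared direction for the change. The two cores differ in more than one place, and these pairs do not show which of those differences goes with the larger step, nor how the change would behave on any further core.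

Open, from the compounds shown here alone, is how the methoxy step runs on a core combining the fluorine of compound 2 with the sulfonamide of compound 3, which would help separate those differences. Also open, going by these compounds, is whether an amine or an ethoxy group on the same aromatic carbon would give numbers closer to those of the methoxy compounds or the hydrogen compounds.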